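The source may report more compounds than this note shows. Statements on the series, on what has been measured and on what is new or still open speak of the compounds shown alone.

Measured in a functional assay on 1321-N1 cells for agonist activity at Free fatty acid receptor 1 (Homo sapiens), read by calcium flux; a lower number here means that less compound is needed, a higher number that more compound is needed for the effect:
compound 1 `O=C(O)CCc1ccc(COc2ccccc2)cc1` gives 6310 nM
compound 2 `O=C(O)CCc1ccc(OCc2cccc(Br)c2)cc1` gives 89.1 nM
compound 3 `N#Cc1cccc(COc2ccc(CCC(=O)O)cc2)c1` gives 525 nM

Compound 3 stands second highest of the three numbers. Going by the values given here, its nearest neighbour is compound 2, and the only single-point step in the set, a 5.9-fold higher number from compound 2 to compound 3 (0.77 log units; beyond the scatter), separates the two. Among the compounds with values here, compound 1 lies furthest away; its value set beside that of compound 3 shows that the analogue carrying neither bromo nor cyano needs far more compound, but compound 1 also has its ether turned the other way round, so no one-change step joins it to compounds 2 or 3.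

Compound 4 `O=C(O)CCc1ccc(OCc2cccc(-c3ccccc3)c2)cc1` differs from compound 3 at one place: phenyl in place of cyano on an aromatic carbon. Within the data shown here, the one measured step bearing on this position, from bromo to cyano, was modest and ran toward a higher number. Nothing measured says directly what phenyl does there; compounds 2 and 3, which carry a group at this position, both sit well below compound 1. On that basis the step in this assay is expected to run back toward a lower number, of a size similar to the bromo-to-cyano step but reversed, so a 5.3-fold lower number from compound 3 to compound 4 (0.72 log units; beyond the scatter) is the expectation. Compound 4 is therefore estimated at 100 nM, with a range from 30 nM to 400 nM.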

Compound 4, half-maximal effective concentration: 135 nM
Compound 4: the middle estimate sits 1.4-fold (0.13 log units) below what was measured; the range from low to high includes it.
By their numbers in this assay, from the lowest: compounds 2 and 4 (each within the scatter of the next); then compound 3; then compound 1.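

In this assay this position accepts a whole aromatic ring: phenyl, with six heavy atoms against two for cyano, gives a 3.9-fold lower number from compound 3 to compound 4 (0.59 log units; beyond the scatter) and so reverses the loss seen on going from bromo to cyano. Against bromo, the same group gives a 1.5-fold higher number from compound 2 to compound 4 (0.18 log units; within the scatter) and therefore stands level with it within the scatter, so a marked increase in heavy-atom count at this aromatic carbon carries no measurable cost relative to bromo. Among the three groups now compared here, cyano alone is separated from both others by steps beyond the scatter, but nothing measured on these compounds accounts for that separation.

Still open, as far as these compounds go, is whether the tolerance extends to a phenyl ring that itself carries a group, such as a methoxy, a carboxylic acid or an amine, or to a saturated ring such as cyclohexyl in the same place. Also open, from the compounds shown here alone, is how a longer chain between the two aromatic rings of the biphenyl part, such as a methylene or an ether link, would compare with the direct attachment of phenyl in compound 4 in this assay.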